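Swapping the Amide Heteroaryl from Compound 1 to Compound 3

The compounds below may be only part of what the source reports. "The series", "measured", "known", "first", "only" and "open" are said of these compounds alone.

Compound 1 `Cc1cnc(NC(=O)COc2ccc(/C=C3\SC(=O)NC3=O)cc2)s1` — < 100000 nM
Compound 2 `O=C(COc1ccc(/C=C2\SC(=O)NC2=O)cc1)Nc1cccc(C(F)(F)F)c1` — < 100000 nM

In a functional assay on HOP-62 cells (Homo sapiens) for cytotoxicity, read by sulforhodamine B assay, with a stated time of 48 h (a higher number here means a weaker inhibitor of growth, a lower number a stronger inhibitor of growth), compound 1 gives < 100000 nM, which is a limit of the assay rather than a number. Compound 2 likewise gives only a limit, < 100000 nM. Compound 1 therefore cannot be ranked against compound 2, since both sit at the limit of < 100000 nM in this assay, at which 2 of the 2 values shown sit.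

Compound 3 `Cc1cc(NC(=O)COc2ccc(/C=C3\SC(=O)NC3=O)cc2)no1` differs from compound 1 by 5-methyl-1,2-oxazol-3-yl in place of 5-methyl-1,3-thiazol-2-yl on an amide-type nitrogen. With both measured values resting at the limit, no step beyond the scatter is expected, and compound 3 is estimated at 60000 nM, within 20000 nM to 150000 nM. The step from compound 1 to compound 3 is thus expected to be a step that the limit leaves unreadable from compound 1 to compound 3.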

Compound 3, concentration for total growth inhibition: < 100000 nM
Compound 3 ended at the assay's limit (the forecaster's own chance of this, stated with the estimate: 65%); the middle value lies beyond the limit too.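

Going by these compounds alone, compound 3, like compound 1, rests at a limit in this assay, so no step between compound 1 and compound 3 can be read. The compounds shown leave open whether 5-methyl-1,2-oxazol-3-yl and 5-methyl-1,3-thiazol-2-yl differ at all in their effect on growth.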